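From a Dibromoaryl Group to a Pentyl Chain

This account rests on a few compounds, and the source may have more. Where it says the series, first, only, none or still open, it means among the compounds named here.

In a physicochemical assay for lipophilicity (a lower number here means a more polar compound, a higher number a more lipophilic compound), compound 2 `COc1cc(Cn2c(=O)cc(N3CCC[C@@H](N)C3)n(Cc3cc(F)ccc3C#N)c2=O)c(Br)c(Br)c1OC` sits in the middle of three values at 4.32, with compound 1 `CC#CCn1c(N2CCC[C@@H](N)C2)cc(=O)n(Cc2cc(OC)c(OC)c(Br)c2Br)c1=O` at 3.21 and compound 3 `COc1c(Br)c(Br)c(Cn2c(=O)cc(N3CCC[C@@H](N)C3)n(Cc3cc(F)ccc3C#N)c2=O)c(Br)c1OC` at 5.15. Compound 4 `CCCCCCn1c(=O)cc(N2CCC[C@@H](N)C2)n(Cc2cc(F)ccc2C#N)c1=O` has pentyl in place of 2,3-dibromo-4,5-dimethoxyphenyl, a change counted as pentyl in place of 2,3-dibromo-4,5-dimethoxyphenyl on a saturated chain carbon bound to an aromatic nitrogen. For the measured compounds named here, two measured steps bear on this. Placing 2-cyano-5-fluorophenyl where prop-1-yn-1-yl stood gave a number 1.11 log units higher from compound 1 to compound 2 (beyond the scatter), and the new change also swaps a ring group and a chain, but in the opposite direction. Adding a bromo gave a number 0.83 log units higher from compound 2 to compound 3 (beyond the scatter), whereas this change removes bromine. A large fall is therefore expected, with an estimated a number 1.02 log units lower from compound 2 to compound 4 (beyond the scatter). Compound 4 is expected at 3.3, within 2.6 to 4.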

Compound 4, partition coefficient: 3.26
Compound 4: the middle estimate sits 0.04 log units above what was measured; the range from low to high includes it.
By their numbers in this assay, from the lowest: compounds 1 and 4 (each within the scatter of the next); then compound 2; then compound 3.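

In this assay, for the compounds shown here, the change gave a number 1.06 log units lower from compound 2 to compound 4 (beyond the scatter) at this position, where compounds 1, 2 and 3 all carry a brominated phenyl ring, so this is the first reading here with an open chain. The swap removes the ring, both bromines and both methoxy groups at once, so the size of the step cannot be divided among them. No measurement shown here explains the fall. Still open, as far as these compounds go, is how an unsubstituted benzene ring, a longer chain such as octyl, or a pentyl chain ending in a carboxylic acid would read at this position.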